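Swapping the Aryl Group on a Shared Trimethoxyphenyl Core

The compounds below may be only part of what the source reports. "The series", "measured", "known", "first", "only" and "open" are said of these compounds alone.

Of the compounds shown here, three built on one shared core have been tested in a functional assay on B16-F0 cells (Mus musculus) for inhibition, read by CCK-8 assay, with a stated time of 48 h; a lower number here means a stronger inhibitor, a higher number a weaker inhibitor. Compound 1 `COc1cc(-c2ccnc3cc(-c4ccc(F)cc4)nn23)cc(OC)c1OC` gives 4540 nM. Compound 2 `COc1cc(-c2ccnc3cc(-c4ccc(C)c(C)c4)nn23)cc(OC)c1OC` gives 391 nM, and compound 3 `COc1cc(-c2ccnc3cc(-c4ccc(C(F)(F)F)cc4)nn23)cc(OC)c1OC` gives 1770 nM. Compound 2 stands lowest of the three: there is a 4.5-fold higher number from compound 2 to compound 3 (0.66 log units; beyond the scatter), and there is a 12-fold lower number from compound 1 to compound 2 (1.06 log units; beyond the scatter). Compound 4 `COc1ccc(-c2cc3nccc(-c4cc(OC)c(OC)c(OC)c4)n3n2)cc1N` carries the change (3-amino-4-methoxyphenyl in place of 3,4-dimethylphenyl on an aromatic carbon). The two steps that bear on this change, a 12-fold lower number from compound 1 to compound 2 (1.06 log units; beyond the scatter) and a 4.5-fold higher number from compound 2 to compound 3 (0.66 log units; beyond the scatter), were both beyond the scatter, so exchanging the group at this place has so far moved the number by a modest to large amount in every case. Among the compounds with values here, no measured compound carries an amino or a methoxy group at this place, so the direction is open and the range must be wide. Compound 4 is expected to give 600 nM, within 150 nM to 2500 nM. That estimate means an expected 1.5-fold higher number from compound 2 to compound 4 (0.19 log units; within the scatter), a step that may well fall within the scatter.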

Compound 4, half-maximal inhibitory concentration: 88 nM
The estimate for compound 4 lay 6.8-fold (0.83 log units) above the measured number; measured number outside the range, below it.
By their numbers in this assay, from the lowest: compound 4; then compound 2; then compound 3; then compound 1.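

Before compound 4, the groups at this place carried only carbon or fluorine on the aromatic ring. 3-amino-4-methoxyphenyl adds nitrogen and oxygen and, unlike 3,4-dimethylphenyl, brings a hydrogen-bond donor and acceptors; in this assay the exchange gives a 4.4-fold lower number from compound 2 to compound 4 (0.65 log units; beyond the scatter), and the gaps to the fluorine-bearing compounds are wider, with a 20-fold lower number from compound 3 to compound 4 (1.30 log units; beyond the scatter) and a 52-fold lower number from compound 1 to compound 4 (1.71 log units; beyond the scatter). The number at this place can therefore go well below that of the best earlier group, though nothing available explains why it does.

Still open, going by these compounds, is how this drop divides between the amino group and the methoxy group. On these data alone, it is also open whether a hydroxyl group or an acetamide in place of the amine would keep the number this low.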